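The source may hold more compounds than are shown below. What is called first, only, known or untested is meant among the compounds shown, and "the series" means these compounds.

Compound 3, with the structure `CN(C)c1ccc(/C=C2\C(=O)N(c3c(Cl)cccc3Cl)c3ccccc32)cc1`, is the only one of the three measured entries that comes with any reading in a functional assay on HuTu80 cells (Homo sapiens) for cytotoxicity, read by MTT assay, with a stated time of 72 h; on this read-out higher numbers stand for an effect only at larger amounts of compound and lower numbers for an effect already at smaller amounts. In this assay compound 3 gives < 1 ug/mL, which is a limit of the assay and not a number; the reading sits at the limit of < 1 ug/mL in this assay, at which 1 of the 3 values shown sits. Compound 1, whose structure is `O=C1/C(=C\c2cc3ccccc3nc2Cl)c2ccccc2N1c1c(Cl)cccc1Cl`, is reported in this assay as "not determined" (no result reported). Compound 2, whose structure is `Cc1ccc2nc(Cl)c(/C=C3\C(=O)N(c4c(Cl)cccc4Cl)c4ccccc43)cc2c1`, is reported in this assay as "not determined" (no result reported). Compound 4, with the structure `O=C1/C(=C\c2ccccc2[N+](=O)[O-])c2ccccc2N1c1c(Cl)cccc1Cl`, has not yet been measured in this assay.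

The change from compound 3 to compound 4 is 2-nitrophenyl in place of 4-(dimethylamino)phenyl on a double-bonded chain carbon bound to a double-bonded ring carbon. Among the measured compounds shown here, no step between two measured compounds is available in this assay to set the size of such a change, and the one reading for compound 3 is itself only a limit.

With that in mind, the step expected from compound 3 to compound 4 is an at least 2.5-fold higher number from compound 3 to compound 4 (0.39 log units; beyond the scatter), a moderate move toward an effect only at larger amounts, with a real chance that the assay again reports only a limit. Compound 4 is therefore expected to give about 2.5 ug/mL in this assay, within a range from 0.5 ug/mL to 15 ug/mL.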

Compound 4, concentration for half-maximal effect: 10 ug/mL
For compound 4 the middle estimate is 4.0-fold (0.60 log units) below the measured one; measured number inside the range.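

This position, on a double-bonded chain carbon bound to a double-bonded ring carbon, now has its first readable step in this assay: 2-nitrophenyl in place of 4-(dimethylamino)phenyl gives an at least 10-fold higher number from compound 3 to compound 4 (1.00 log units; beyond the scatter) and so shows that the group carried here changes the reading. Compound 3 stands at < 1 ug/mL and that is a limit of the assay, not a number. The step therefore gives only a lower bound on the true difference, because one end of it rests on that limit: the limit of < 1 ug/mL in this assay, at which 1 of the 4 values shown sits.

Among the compounds shown here, compound 1 and compound 2 carry no result, so no steps to them can be read, and this single pair cannot separate the loss of the dimethylamino group from the arrival of the nitro group. As far as these compounds go, what an unsubstituted phenyl, or a phenyl bearing a morpholine or a carboxylic acid, would give at this position remains open, as does whether the shared core keeps the same sensitivity to this change with other groups in place.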